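A few compounds are considered here, and "the series" means these few. Any claim that something is new, unique, unknown or untested is made for them only; others in the source may bear on it.

Measured compounds:
Compound 1, `Cn1cncc1CN1CC(N(CC2CCN(C(=O)c3ccc(Cl)cc3)CC2)S(=O)(=O)c2ccccn2)Cc2cc(C#N)ccc21`: 0.5 10^-6 cm/s
Compound 2, `Cn1cncc1CN1CC(N(CC2CCN(C(=O)NC(C)(C)C)CC2)S(=O)(=O)c2ccccn2)Cc2cc(C#N)ccc21`: 0.6 10^-6 cm/s
Compound 3, `CCS(=O)(=O)N1CCC(CN(C2Cc3cc(C#N)ccc3N(Cc3cncn3C)C2)S(=O)(=O)c2ccccn2)CC1`: 0.1 10^-6 cm/s

These three compounds share one core and differ only in the group on an amine nitrogen in a ring of the six-membered non-aromatic ring. In an ADME assay on Caco-2 cells (Homo sapiens) for permeability, in the apical to basolateral direction (a higher number here means that the compound crosses the layer faster, a lower number that the compound crosses the layer more slowly), compound 3 stands lowest of the three numbers; its nearest neighbour is compound 1, from which it is separated by a 5.0-fold lower number from compound 1 to compound 3 (0.70 log units; beyond the scatter), and the other step is a 6.0-fold lower number from compound 2 to compound 3 (0.78 log units; beyond the scatter). Compound 1 and compound 2 are separated by a 1.2-fold higher number from compound 1 to compound 2 (0.08 log units; within the scatter), so the two carbonyl-bearing groups give numbers that cannot be told apart.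

Compound 4, `Cn1cncc1CN1CC(N(CC2CCN(C(=O)c3cccs3)CC2)S(=O)(=O)c2ccccn2)Cc2cc(C#N)ccc21`, has not yet been measured in this assay. It differs from compound 3 by (thiophen-2-yl)carbonyl in place of ethylsulfonyl on an amine nitrogen in a ring. Among the compounds with values here, the step that bears most directly on this change is the one from compound 1 to compound 3, where a carbonyl-bearing aromatic group gave way to ethylsulfonyl; the step from compound 2 to compound 3 points the same way and is of similar size. Compound 4 returns a carbonyl group bearing an aromatic ring to that nitrogen, so the account expects a step of a 4.0-fold higher number from compound 3 to compound 4 (0.60 log units; beyond the scatter), upward, comparable in size to the earlier two. The estimate for compound 4 in this assay is 0.4 10^-6 cm/s, with a range from 0.15 10^-6 cm/s to 1 10^-6 cm/s.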

Compound 4, apparent permeability: 0.5 10^-6 cm/s
For compound 4 the middle estimate is 1.3-fold (0.10 log units) below the measured one, within the range that was stated.
By their numbers in this assay, from the lowest: compound 3; then compounds 1, 4 and 2 (each within the scatter of the next).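

At the amine nitrogen in a ring, this assay now shows a third carbonyl-bearing group standing clear of ethylsulfonyl, with a 5.0-fold higher number from compound 3 to compound 4 (0.70 log units; beyond the scatter) in this exchange of ethylsulfonyl for (thiophen-2-yl)carbonyl. What stands on the carbonyl carbon makes no difference that can be read here: thiophen-2-yl in place of 4-chlorophenyl gives no change at the digits printed from compound 1 to compound 4 (within the scatter) and thiophen-2-yl in place of (tert-butyl)amino gives a 1.2-fold lower number from compound 2 to compound 4 (0.08 log units; within the scatter) within the scatter, so a five-membered aromatic ring now joins a six-membered aromatic ring and a non-aromatic amino group on that carbon with numbers that cannot be told apart. Across these four compounds the divide therefore runs between the carbonyl-bearing groups and ethylsulfonyl, and no compound shown goes against it, although ethylsulfonyl rests on compound 3 alone.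

The compounds shown leave open whether another sulfonyl group, such as phenylsulfonyl or a longer chain on the sulfur, would stand with compound 3 or with the others, and what a plain methyl group or an unsubstituted ring amine would give at this nitrogen. Nothing among the data shown offers a measured reason for the divide.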